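The compounds below may be only part of what the source reports. "The series", "measured", "known", "first", "only" and "open" are said of these compounds alone.

Among the compounds with values here, the three compounds measured so far share one core and differ only at an amide-type nitrogen. Compound 1 `CCC1C(=O)N(C)c2cnc(-n3ccc4cc(C(N)=O)ccc43)nc2N1c1ccn(C)n1` carries hydrogen there and gives 384 nM in an assay for inhibition of serine/threonine-protein kinase PLK2 (Homo sapiens), read by FRET and Z'-LYTE, with a stated time of 1 h; on this read-out higher numbers stand for weaker inhibition and lower numbers for stronger inhibition. Compound 2 `CCC1C(=O)N(C)c2cnc(-n3ccc4cc(C(=O)NC(C)C)ccc43)nc2N1c1ccn(C)n1` carries isopropyl and gives 125 nM. Compound 3 `CCCCNC(=O)c1ccc2c(ccn2-c2ncc3c(n2)N(c2ccn(C)n2)C(CC)C(=O)N3C)c1` carries butyl and gives 159 nM, the second highest number of the three; its nearest neighbour is compound 2, within the scatter, and its furthest is compound 1, beyond the scatter. Compound 4 `CCC1C(=O)N(C)c2cnc(-n3ccc4cc(C(=O)NC5CCCC5)ccc43)nc2N1c1ccn(C)n1` is not yet measured; it differs from compound 3 in one place: cyclopentyl in place of butyl on an amide-type nitrogen.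

Within the data shown here, two steps bear on this change. Replacing hydrogen by isopropyl gave a 3.1-fold lower number from compound 1 to compound 2 (0.49 log units; beyond the scatter), and replacing hydrogen by butyl gave a 2.4-fold lower number from compound 1 to compound 3 (0.38 log units; beyond the scatter); both are modest and in the same direction. The comparison most like the present one, butyl in place of isopropyl, gave a 1.3-fold higher number from compound 2 to compound 3 (0.10 log units; within the scatter), within the scatter. Taken together these suggest that once an alkyl group sits on the amide-type nitrogen, changing its shape does little. Compound 4 is therefore expected to stay close to compound 3, with a step of a 1.2-fold lower number from compound 3 to compound 4 (0.09 log units; within the scatter) that lies within the scatter. Compound 4 is estimated at 130 nM, with a range from 60 nM to 280 nM.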

Compound 4, half-maximal inhibitory concentration: 90.9 nM
For compound 4 the middle estimate is 1.4-fold (0.16 log units) above the measured one, within the range that was stated.
By their numbers in this assay, from the lowest: compounds 4, 2 and 3 (each within the scatter of the next); then compound 1.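

In this assay the amide-type nitrogen now proves to accept a ring as well as an open chain: cyclopentyl, the only ring seen at this place, shows a 1.7-fold lower number from compound 3 to compound 4 (0.24 log units; within the scatter) when it replaces butyl and a 1.4-fold lower number from compound 2 to compound 4 (0.14 log units; within the scatter) when it replaces isopropyl, so neither step sets it apart from the open groups. The separation from hydrogen also holds for this third carbon-only group, with a 4.2-fold lower number from compound 1 to compound 4 (0.63 log units; beyond the scatter) on going from the amide hydrogen to cyclopentyl, and none of the compounds shown goes against this pattern of compound 2, compound 3 and compound 4 standing apart from compound 1. No accompanying measurement speaks to what lies behind these numbers.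

The compounds shown leave open how far this acceptance extends, for instance to a larger ring such as cyclohexyl or phenyl, or to a smaller group such as methyl. They also leave open whether a chain ending in an amine or a carboxylic acid would stay with the carbon-only groups or fall back towards compound 1.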